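The compounds below may be only part of what the source reports. "The series", "measured", "known", "first", "only" and "open" are said of these compounds alone.

Measured so far:
compound 1, `NC(=O)c1cc[n+](CCCC[n+]2ccc(/C=N/O)cc2)cc1`: 0.34 10^-6 cm/s
compound 2, `NC(=O)c1cc[n+](CCC[n+]2cc(Cl)c(/C=N/O)c(Cl)c2)cc1`: 1.73 10^-6 cm/s

Going by the values given here, in an ADME assay for permeability, using PAMPA, with a stated time of 6 h, tested at 100 uM (a lower number here means that the compound crosses the layer more slowly, a higher number that the compound crosses the layer faster), compound 1 gives 0.34 10^-6 cm/s, the lower of the two numbers known here. Compound 2 gives 1.73 10^-6 cm/s in this assay, a number that stands beyond the scatter above that of compound 1. Among the compounds with values here, no step between two measured compounds that differ in a single place has been determined, so the effect of the change below can only be guessed.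

Compound 3, `NC(=O)c1cc[n+](CCCC[n+]2ccc(/C=N/O)c(Cl)c2)cc1`, differs from compound 1 in one place: chloro in place of hydrogen on an aromatic carbon. Compound 3 has not yet been measured in this assay. Compound 1 stands at the bottom of what is known, and compound 2, which carries chloro groups on the same kind of ring, gives 1.73 10^-6 cm/s. On this basis compound 3 is expected to give a somewhat higher number than compound 1, an estimated step of a 2.1-fold higher number from compound 1 to compound 3 (0.31 log units; beyond the scatter), though a step within the scatter cannot be ruled out. The estimate for compound 3 in this assay is 0.7 10^-6 cm/s, with a range from 0.3 10^-6 cm/s to 1.6 10^-6 cm/s.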

Compound 3, apparent permeability: 1 10^-6 cm/s
Estimate against measurement, compound 3: 1.4-fold (0.15 log units) below; the measured number falls inside the stated range.
By their numbers in this assay, from the lowest: compound 1; then compounds 3 and 2 (each within the scatter of the next).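

In this assay, going by these compounds alone, chloro in place of hydrogen on an aromatic carbon gives a 2.9-fold higher number from compound 1 to compound 3 (0.47 log units; beyond the scatter), and this is the first step between measured compounds that differ in one place. It shows that this position, two atoms from the ring nitrogen, takes a single chlorine atom with a modest rise in the number, a rise that lies beyond the scatter. No measurement at hand accounts for this step.

Going by these compounds, whether fluoro, methoxy or an amine at the same position would give a step of similar size remains open. So does whether chloro would give the same step with a longer chain in the core of compound 3.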